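Notes on a ring swap at the amine-bearing core

This account rests on a few compounds, and the source may have more. Where it says the series, first, only, none or still open, it means among the compounds named here.

Compound 2 `Nc1nc(-c2ncco2)nc2sc(Cc3ccccc3)cc12` is the reference point here. In a functional assay on CHO-K1 cells for antagonist activity at adenosine receptor A1 (Homo sapiens), read by a beta-galactosidase reporter and cAMP accumulation, with stated times of 15 min and 6 h (a higher number here means a weaker inhibitor, a lower number a stronger inhibitor), compound 2 gives 310 nM, the lowest of the two numbers recorded so far. Compound 1 `N#Cc1ccc(-c2nc(N)c3cc(Cc4ccccc4)sc3n2)o1` gives 3160 nM, and the single-point change from it, 1,3-oxazol-2-yl in place of 5-cyanofuran-2-yl on an aromatic carbon, produced a 10-fold lower number from compound 1 to compound 2 (1.01 log units; beyond the scatter). Compound 3 `C=C(c1ccccc1)c1cc2c(N)nc(-c3nc(C)cs3)nc2s1` returned only a limit, > 594 nM, and the limit of > 594 nM in this assay, at which 1 of the 3 values shown sits, is all that can be said of it.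

Compound 4 `N#Cc1cccc(-c2nc(N)c3cc(Cc4ccccc4)sc3n2)c1` is the next point. Relative to compound 2 the change is 3-cyanophenyl in place of 1,3-oxazol-2-yl on an aromatic carbon.

Only the measured step from compound 1 to compound 2 bears on this, since it concerns the same position and the same kind of exchange of an aromatic substituent, and it was large. It also shows that the nitrile-bearing ring of compound 1 sat at the higher number. With a nitrile again present on the incoming 3-cyanophenyl, and a six-membered ring entering where a five-membered one leaves, the expectation is for a move back toward higher numbers, of moderate size. For compound 4 the estimate in this assay is 1200 nM, within 250 nM to 6000 nM, which as a step is expected to be a 3.9-fold higher number from compound 2 to compound 4 (0.59 log units; beyond the scatter).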

Compound 4, inhibition constant: 222 nM
Compound 4: middle estimate off by 5.4-fold (0.73 log units), on the high side; measured number below the stated range.
By their numbers in this assay, from the lowest: compounds 4 and 2 (each within the scatter of the next); then compound 1.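

In this assay, this place on the core takes 3-cyanophenyl, with 8 heavy atoms, as well as 1,3-oxazol-2-yl, with 5 (a 1.4-fold lower number from compound 2 to compound 4 (0.15 log units; within the scatter)), so a six-membered aromatic ring of carbon only is not separated here from a five-membered aromatic ring with 2 hetero atoms. The large step from the other nitrile-bearing compound (a 14-fold lower number from compound 1 to compound 4 (1.15 log units; beyond the scatter)) shows that a nitrile on the ring does not by itself go with the higher number, since compound 1 and compound 4 both carry one and sit far apart. Nothing measured on these compounds accounts for either step.

The compounds shown do not separate the part played by the furan ring in compound 1 from that of its nitrile, a question that plain furan-2-yl and unsubstituted phenyl at this place would address. From the compounds shown here alone, it also stays open whether the nitrile of 3-cyanophenyl contributes at all, or whether an amine, a carboxylic acid or a longer chain on that ring would be taken as well as the nitrile is.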